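The source may hold more compounds than are shown below. What is called first, only, known or untested is meant among the compounds shown, and "the series" means these compounds.

Among the compounds with values here, compound 1, with the structure `CC(C)(C)/N=C(\NC#N)Nc1ccc(C#N)cc1`, is the only compound here with a definite number in an assay on membranes from heart (Canis lupus familiaris) for displacement of a labelled ligand from sulfonylurea receptor 2, Kir6.2 (Homo sapiens); on this read-out lower numbers stand for stronger inhibition and higher numbers for weaker inhibition; in this assay compound 1 gives 480 nM. Compound 2, built as `CCC(C)(C)/N=C(\NC#N)Nc1cccc(S(=O)(=O)N2CCCCC2)c1`, yields only a limit in this assay, namely > 30000 nM, which is a limit of the assay and not a number. That is the point described by the limit of > 30000 nM in this assay, at which 1 of the 2 values shown sits. Within the data shown here, compound 2 differs from compound 1 in more than one place, so the two values show only that compound 1 has a measured number and compound 2 does not.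

Compound 3, drawn as `CCC(C)(C)/N=C(\NC#N)Nc1ccc(C#N)cc1`, has not yet been measured in this assay. It differs from compound 1 by methyl in place of hydrogen on a saturated chain carbon, two bonds along the chain from a double-bonded nitrogen, with the rest of compound 1 kept. Among the measured compounds shown here, no step between two measured compounds in this set covers that change on its own. The step expected here, a 1.5-fold higher number from compound 1 to compound 3 (0.16 log units; within the scatter), is estimated to be small, likely within the usual scatter, with a slight lean toward weaker binding. Compound 3 is therefore expected to give about 700 nM in this assay, within a range from 250 nM to 2500 nM.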

Compound 3, inhibition constant: 160 nM
Estimate against measurement, compound 3: 4.4-fold (0.64 log units) above, outside the stated range (below it).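

Methyl in place of hydrogen at this saturated chain carbon, which turns tert-butyl into 1,1-dimethylpropyl, gives a 3.0-fold lower number from compound 1 to compound 3 (0.48 log units; beyond the scatter) in this assay and so lies beyond the usual scatter. Within the data shown here, this is the first comparison here that isolates one change, and it shows that the read-out responds to a single added carbon at this end of the molecule, with the larger group going with stronger inhibition rather than weaker. Nothing given here explains why the number falls, and no available evidence bears on the cause of this step.

As far as these compounds go, whether the trend continues at this carbon remains open: a longer chain such as propyl, a ring such as cyclopentyl or an oxygen-bearing group such as hydroxyl could lower the number further, leave it unchanged or raise it. From the compounds shown here alone, the step also rests on a single pair, so it is unknown whether the same methyl change would lower the number if a carboxylic acid or an amine took the place of the nitrile on the shared core.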